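Piperazine variation on the shared core, agonist calcium flux

A few compounds are considered here, and "the series" means these few. Any claim that something is new, unique, unknown or untested is made for them only; others in the source may bear on it.

Measured so far:
- compound 1, `C[C@@H]1CN(c2cccc3c2C[C@H](CN(C)[C@H]2CCCc4cccnc42)NC3)C[C@H](C)N1`: > 30000 nM
- compound 2, `Cc1cnc(CN(C)C[C@H]2Cc3c(cccc3N3CCNCC3)CN2)c(C)c1`: > 30000 nM

In a functional assay on CCRF-CEM cells for agonist activity at C-X-C chemokine receptor type 4 (Homo sapiens), read by calcium flux, with a stated time of 25 min (a higher number here means that more compound is needed for the effect, a lower number that less compound is needed), compound 1 gives > 30000 nM, which is a limit of the assay and not a number. In this assay compound 2 likewise gives > 30000 nM, again a limit rather than a number. Both values sit at the limit of > 30000 nM in this assay, at which 2 of the 2 values shown sit, so compound 1 stands nowhere in particular on the numbers shown: it is indistinguishable from compound 2, and no step between measured compounds can be read.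

Compound 3, `CCN1CCN(c2cccc3c2C[C@H](CN(C)[C@H]2CCCc4cccnc42)NC3)CC1`, has not yet been measured in this assay. It carries 4-ethylpiperazin-1-yl in place of 3,5-dimethylpiperazin-1-yl on an aromatic carbon. The two compounds have the same atoms, joined differently.

With both measured compounds at the limit, no step size can be drawn from the data. The expectation for compound 3 is therefore no change beyond the scatter, with the step from a number no higher from compound 1 to compound 3 (the limit leaves the size open) expected to be essentially flat. Compound 3 is estimated at 30000 nM in this assay, within 10000 nM to 100000 nM, and most likely reported as a limit only.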

Compound 3, half-maximal effective concentration: > 30000 nM
Compound 3 gave a limit, no number (the forecaster's own chance of this, stated with the estimate: 85%); the middle value lies on the limit itself.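

In this assay compound 3 gives > 30000 nM, which is a limit of the assay and not a number. No step can be read between compound 1 and compound 3, and the values shown offer no comparison: the limit of > 30000 nM in this assay, at which 3 of the 3 values shown sit. The compounds shown leave open whether any piperazine variation on the shared core gives a half-maximal effective concentration that can be stated as a number in this assay.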